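The source may hold more compounds than are shown below. What is called first, only, known or untested is meant among the compounds shown, and "the series" means these compounds.

Measured compounds:
compound 1, `Nc1nc(-c2ccc(C3CC3)o2)nc2sc(Cc3ccccc3)cc12`, in a functional assay on CHO-K1 cells for antagonist activity at adenosine receptor A1 (Homo sapiens), read by a beta-galactosidase reporter and cAMP accumulation, with stated times of 15 min and 6 h (a lower number here means a stronger inhibitor, a higher number a weaker inhibitor), compound 1 gives 861 nM;
compound 2, `COc1ccccc1Cc1cc2c(N)nc(-c3cccc(C#N)c3)nc2s1`, in this assay compound 2 gives 129 nM;
compound 3, `N#Cc1cccc(-c2nc(N)c3cc(Cc4ccccc4Cl)sc3n2)c1`, in this assay compound 3 gives 24.8 nM.

Compound 1 gives the highest number of the three in this assay; compound 2 sits nearest to it and compound 3 furthest, both with lower numbers that lie beyond the scatter of compound 1. Among the compounds with values here, the only step between measured compounds that differ in one place is a 5.2-fold lower number from compound 2 to compound 3 (0.72 log units; beyond the scatter), a change on the benzyl ring rather than on the shared core, so it does not bear directly on the change now considered.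

Compound 4, `N#Cc1cccc(-c2nc(N)c3cc(Cc4ccccc4)sc3n2)n1`, differs from compound 1 in one place: 6-cyanopyridin-2-yl in place of 5-cyclopropylfuran-2-yl on an aromatic carbon. Within the data shown here, no measured pair isolates this change. What the numbers do show is that compound 2 and compound 3, which both carry a nitrile-bearing aromatic ring at that place, give lower numbers than compound 1; those two compounds also carry substituted benzyl groups, so the comparison is not clean. On that basis compound 4 is expected to give a lower number than compound 1 in this assay, a step of a 3.4-fold lower number from compound 1 to compound 4 (0.54 log units; beyond the scatter), with wide uncertainty. The estimate for compound 4 is 250 nM, between 70 nM and 900 nM.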

Compound 4, inhibition constant: > 1000 nM
Compound 4 was reported as a limit; the forecaster's own chance of this, stated with the estimate: 5%; at least 4.0-fold (0.60 log units) between middle value and limit.
By their numbers in this assay, from the lowest: compound 3; then compound 2; then compound 1. At a limit, above all of these: compound 4.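

In this assay, the result for compound 4 is a limit and not a number: the limit of > 1000 nM in this assay, at which 1 of the 4 values shown sits.

Within the data shown here, this gives the first direct reading of a change at this position, the aromatic carbon between two ring nitrogen atoms, where no earlier pair of compounds isolated a change: 6-cyanopyridin-2-yl in place of 5-cyclopropylfuran-2-yl gives an at least 1.1-fold higher number from compound 1 to compound 4 (0.06 log units; that floor lies within the scatter). With the unsubstituted benzyl group of compound 1 kept in place, the entering group therefore brings no lower number, although the floor of this step does not by itself establish a real rise.

The compounds shown leave open how far the true number of compound 4 lies from that of compound 1, and whether the chloro group on the benzyl ring of compound 3 would bring a lower number if it were placed on compound 4. They also leave open how this position would read with a plain phenyl ring, or with a carboxylic acid or a primary amine in place of the nitrile on 6-cyanopyridin-2-yl.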